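Compound 3 to compound 4: leaving the phenyl amides

The source may report more compounds than this note shows. Statements on the series, on what has been measured and on what is new or still open speak of the compounds shown alone.

Measured in a functional assay on A549 cells (Homo sapiens) for inhibition, read by MTT assay, with a stated time of 72 h; on this read-out lower numbers stand for stronger inhibition and higher numbers for weaker inhibition
compound 1 `O=C(CCC(=O)OCCCCCCSc1ccc([N+](=O)[O-])c2nonc12)Nc1ccccc1Cl` gives 2750 nM
compound 2 `O=C(CCC(=O)OCCCCCCSc1ccc([N+](=O)[O-])c2nonc12)Nc1cccc(Cl)c1` gives 5290 nM
compound 3 `COc1ccc(NC(=O)CCC(=O)OCCCCCCSc2ccc([N+](=O)[O-])c3nonc23)cc1OC` gives 3890 nM

Compound 3 stands with the other two. The measured steps are a 1.4-fold higher number from compound 1 to compound 3 (0.15 log units; within the scatter) and a 1.4-fold lower number from compound 2 to compound 3 (0.13 log units; within the scatter) and a 1.9-fold higher number from compound 1 to compound 2 (0.28 log units; within the scatter) and all three stay within the scatter. The change to compound 4 `O=C(CCC(=O)OCCCCCCSc1ccc([N+](=O)[O-])c2nonc12)NCCN1CCCC1` is 2-(pyrrolidin-1-yl)ethyl in place of 3,4-dimethoxyphenyl on an amide-type nitrogen and reads 2-(pyrrolidin-1-yl)ethyl in place of 3,4-dimethoxyphenyl on an amide-type nitrogen. The measured steps only exchange one substituted phenyl for another, so they bear on this change indirectly. No step beyond the scatter is expected in this assay and the uncertainty stays wide. The estimated step is a 1.1-fold lower number from compound 3 to compound 4 (0.05 log units; within the scatter) on this evidence. Compound 4 is estimated at 3500 nM with an expected range from 1200 nM to 10000 nM in this series.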

Compound 4, half-maximal inhibitory concentration: 3240 nM
Beside the measured number, compound 4's estimate is 1.1-fold (0.03 log units) above it, and the stated range covers the measured number.
By their numbers in this assay, from the lowest: compounds 1, 4, 3 and 2 (each within the scatter of the next).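

In this assay the amide-type nitrogen gives no step beyond the scatter when the substituted phenyl groups give way to 2-(pyrrolidin-1-yl)ethyl: the readings are a 1.2-fold lower number from compound 3 to compound 4 (0.08 log units; within the scatter) and a 1.6-fold lower number from compound 2 to compound 4 (0.21 log units; within the scatter) and a 1.2-fold higher number from compound 1 to compound 4 (0.07 log units; within the scatter). Within the data shown here, this position, until now seen only with substituted phenyl groups, therefore also accepts a group with a non-aromatic ring and no aromatic one. No supporting data bear on this result.

Still open, as far as these compounds go, is whether a carboxylic acid, a morpholine or a longer chain in place of 2-(pyrrolidin-1-yl)ethyl on the same nitrogen would move the number beyond the scatter.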